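Little Toxicity Expected From a Swapped Aryl Group

This account rests on a few compounds, and the source may have more. Where it says the series, first, only, none or still open, it means among the compounds named here.

Values in an ADME assay on MT2 cells (Homo sapiens) for cytotoxicity, read by XTT assay, with a stated time of 4 days; on this read-out lower numbers stand for higher toxicity in this test and higher numbers for lower toxicity in this test:
- compound 1 `Cc1ccc(NC(=O)C(=O)NC(c2nc(C)c(CCO)s2)C2CCCCN2)cc1F`: 85000 nM
- compound 2 `Cc1nc(C(NC(=O)C(=O)Nc2ccc(Cl)cc2)C2CCCNC2)sc1CO`: > 81000 nM
- compound 3 `Cc1ccc(NC(=O)C(=O)NC(c2nc(C)c(CO)s2)C2CCCCN2)cc1F`: > 88000 nM

Among the measured compounds shown here, compound 1 gives the only exact number here, 85000 nM. Compound 2 reaches only a limit of the assay, > 81000 nM. Compound 3 also reaches only a limit, > 88000 nM.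

Compound 4 `Cc1nc(C(NC(=O)C(=O)Nc2ccc(F)cc2F)C2CCCCN2)sc1CCO` changes compound 1 as follows: 2,4-difluorophenyl in place of 3-fluoro-4-methylphenyl on an amide-type nitrogen. In words, 2,4-difluorophenyl stands in place of 3-fluoro-4-methylphenyl on an amide-type nitrogen. For the measured compounds named here, the one measured step, an at least 1.0-fold higher number from compound 1 to compound 3 (0.01 log units; that floor lies within the scatter), lies elsewhere on the molecule, so it offers only indirect guidance. Going by the values given here, no measured step covers this exchange itself. The expected result is a 1.1-fold lower number from compound 1 to compound 4 (0.04 log units; within the scatter), with no change beyond the scatter. The estimate for compound 4 is 78000 nM, with an expected range from 35000 nM to 100000 nM.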

Compound 4, half-maximal cytotoxic concentration: > 105000 nM
Compound 4 gave a limit, no number; the forecaster's own chance of this, stated with the estimate: 55%; middle value at least 1.3-fold (0.12 log units) from the limit.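

Compound 4 ends at a limit of the assay, not at a number: the limit of > 105000 nM in this assay, at which 1 of the 4 values shown sits. Among the compounds shown here, this is the first look at the aryl group on the amide-type nitrogen, and in this assay the exchange gives an at least 1.2-fold higher number from compound 1 to compound 4 (0.09 log units; that floor lies within the scatter). So 2,4-difluorophenyl shows no sign of higher toxicity in this test than 3-fluoro-4-methylphenyl, whereas the earlier step changed only the hydroxyalkyl chain.

From the compounds shown here alone, how far compound 4 truly stands from compound 1 stays unknown. Also open, going by these compounds, is how a phenyl group carrying an amine or a carboxylic acid would read at this place.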